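The source may hold more compounds than are shown below. What is called first, only, known or untested is meant among the compounds shown, and "the series" means these compounds.

Compound 1 `Cc1noc(-c2cc3ccccc3[nH]2)n1`: in a functional assay on Jurkat cells (Homo sapiens) for antiproliferative activity, read by WST assay, with a stated time of 72 h (on this read-out higher numbers stand for weaker inhibition and lower numbers for stronger inhibition), compound 1 gives > 50000 nM, which is a limit of the assay and not a number.
Compound 2 `Clc1ccc(-c2noc(-c3cc4ccccc4[nH]3)n2)cc1`: in this assay compound 2 gives > 50000 nM, again a limit of the assay.

For the measured compounds named here, the one measured step, a step that the two limits leave unreadable from compound 1 to compound 2, is therefore unreadable, since (the limit of > 50000 nM in this assay, at which 2 of the 2 values shown sit). Compound 2 thus stands at the limit of this assay, with no number of its own to build on.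

Compound 3 `O=[N+]([O-])c1ccc2[nH]c(-c3nc(-c4ccc(Cl)cc4)no3)cc2c1` differs from compound 2 by nitro in place of hydrogen on an aromatic carbon. Going by the values given here, no measured step bears on such a change: the only step known is hidden behind two limits, so its size is not known. With nothing to point either way, the step from compound 2 to compound 3 is expected to be a step that the limit leaves unreadable from compound 2 to compound 3, that is, no change beyond the scatter. Compound 3 is accordingly estimated at 60000 nM in this assay, within 20000 nM to 200000 nM, and most likely reported again only as a limit.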

Compound 3, half-maximal inhibitory concentration: > 50000 nM
Compound 3 was reported as a limit; the forecaster's own chance of this, stated with the estimate: 85%; the middle value does not contradict the limit.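

For the compounds shown here, compound 3, like compound 2, gives only a limit in this assay and not a number, so no step between them can be read: (the limit of > 50000 nM in this assay, at which 3 of the 3 values shown sit). The compounds shown leave open whether any change on the shared core gives a readable value in this assay at all.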